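This account rests on a few compounds, and the source may have more. Where it says the series, first, only, none or still open, it means among the compounds named here.

Measured compounds:
- compound 1, `COc1ccc2cc([C@H](C)c3nnc(SCc4ccc(Cl)cc4)n3-c3ccc(F)cc3)ccc2c1`: 57400 nM
- compound 2, `COc1ccc(CSc2nnc([C@@H](C)c3ccc4cc(OC)ccc4c3)n2-c2ccc(Cl)cc2)cc1`: 72600 nM

Both compounds were tested in a functional assay on DU-145 cells (Homo sapiens) for cytotoxicity, read by MTT assay (a higher number here means a weaker inhibitor, a lower number a stronger inhibitor), a cell-based measurement of how strongly a compound holds back the growth of a prostate cancer cell line. In this assay compound 1 gives 57400 nM, and compound 2 gives 72600 nM. Compound 2 has the higher of the two numbers, but the gap to compound 1 is within the usual scatter, so the two cannot be told apart; both are weak.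

The next compound, compound 3, `COc1ccc2cc([C@H](C)c3nnc(SCc4ccc(F)cc4)n3-c3ccc(Cl)cc3)ccc2c1`, differs from compound 2 in a single place: fluoro in place of methoxy on an aromatic carbon. The change is small, from a 4-methoxybenzyl group to a 4-fluorobenzyl group, and the rest of the molecule is untouched. Within the data shown here, no measured pair in this set shows what this exchange does. Among the measured compounds shown here, the only guide is that compound 1 and compound 2 sit close together despite differing in several places, which suggests the shared core sets the weak level. The step of a 1.2-fold lower number from compound 2 to compound 3 (0.08 log units; within the scatter) is therefore expected to stay within the scatter, in no particular direction. Compound 3 is estimated at 60000 nM, with a likely range from 25000 nM to 150000 nM.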

Compound 3, half-maximal inhibitory concentration: 33600 nM
The estimate for compound 3 lay 1.8-fold (0.25 log units) above the measured number; the measured number falls inside the stated range.
By their numbers in this assay, from the lowest: compounds 3, 1 and 2 (each within the scatter of the next, the first and the last beyond it).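

The exchange of methoxy for fluoro on this aromatic carbon gives a 2.2-fold lower number from compound 2 to compound 3 (0.33 log units; beyond the scatter) in this assay. Among these compounds, this is the first pair here that differs in one place, and it shows that the group at this position can move the number past the usual scatter, though only modestly: compound 3, at 33600 nM, is still a weak compound. No measurement shown here accounts for the change in this pair.

This single pair cannot separate an effect of adding fluoro from an effect of removing methoxy, and it cannot show how far the number could move at this position, which a plain hydrogen, an amine or a carboxylic acid on the same aromatic carbon would help to settle. Among the compounds shown here, it also leaves open whether the exchange of methoxy for fluoro would give a similar step with a different group on the rest of the molecule, since it has been read only once, against the single background that compound 2 and compound 3 share.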